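Urea-to-carbamate swap on the hexyl chain of the shared core

This account rests on a few compounds, and the source may have more. Where it says the series, first, only, none or still open, it means among the compounds named here.

Measured so far:
compound 1, `CCOC(=O)CC(C)CCCCCn1c(C)nc(-c2ccccc2)c1-c1ccccc1`, 130 nM
compound 2, `Cc1nc(-c2ccccc2)c(-c2ccccc2)n1CCCCCCNC(=O)Nc1ccccc1`, 10000 nM

Among the compounds with values here, in an assay on H4 cells for inhibition of Fatty-acid amide hydrolase 1 (Homo sapiens) (on this read-out lower numbers stand for stronger inhibition and higher numbers for weaker inhibition), compound 2 stands as the higher of the two numbers; the one measured step, a 77-fold higher number from compound 1 to compound 2 (1.89 log units; beyond the scatter), separates it from compound 1. Compound 3, `Cc1nc(-c2ccccc2)c(-c2ccccc2)n1CCCCCCNC(=O)Oc1ccccc1`, is not yet measured. It differs from compound 2 by phenoxy in place of anilino on a carbonyl carbon. Within the data shown here, no measured step covers this kind of change: the only step available, a 77-fold higher number from compound 1 to compound 2 (1.89 log units; beyond the scatter), replaces the whole end of the chain and says little about an exchange confined to the carbonyl carbon. The expectation is therefore weakly founded. Given that compound 2 already sits at the high end of the series, a move back toward the number of compound 1 is taken as the more likely outcome, but with wide uncertainty. For compound 3 the estimate is 1000 nM, between 60 nM and 10000 nM, which would mean an expected step of a 10-fold lower number from compound 2 to compound 3 (1.00 log units; beyond the scatter).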

Compound 3, half-maximal inhibitory concentration: 5.3 nM
Estimate against measurement, compound 3: 190-fold (2.28 log units) above, and the stated range ends above it.
By their numbers in this assay, from the lowest: compound 3; then compound 1; then compound 2.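

In this assay, the exchange confined to the carbonyl carbon, phenoxy in place of anilino, gives a 1900-fold lower number from compound 2 to compound 3 (3.28 log units; beyond the scatter) with the chain and the shared core unchanged, so this single atom change in the linking group, with one hydrogen-bond donor leaving and one acceptor entering by the count, is enough to turn the weakest compound of the set into the strongest. The replacement of the whole chain end also reads in favour of the carbamate, with a 25-fold lower number from compound 1 to compound 3 (1.39 log units; beyond the scatter), which the step from compound 1 to the urea gave no hint of. No measured evidence accounts for the size of this step.

Still open, as far as these compounds go, is whether the phenyl ring on the oxygen is needed or an ethoxy would hold the number. Also open, from the compounds shown here alone, is how the phenoxy carbonyl end behaves on a shorter or a longer chain.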